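A few compounds are considered here, and "the series" means these few. Any claim that something is new, unique, unknown or untested is made for them only; others in the source may bear on it.

In a functional assay on HCT-116 cells (Homo sapiens) for inhibition, read by fluorescence, with a stated time of 48 h (on this read-out lower numbers stand for stronger inhibition of growth and higher numbers for weaker inhibition of growth), compound 3 (`CC(=O)OCC(C)(C)COC1(c2ccc(Cl)cc2)c2ccccc2C(=O)N1Cc1ccccc1`) gives 70000 nM, which lies within the scatter of compound 2 (`CC(C)(CO)COC1(c2ccc(Cl)cc2)c2ccccc2C(=O)N1Cc1ccccc1`) at 82000 nM and of compound 1 (`N[C@H](C(=O)OCCCOC1(c2ccc(Cl)cc2)c2ccccc2C(=O)N1Cc1ccccc1)c1ccccc1`) at 43000 nM. Compound 4 (`CC(C)[C@H](N)C(=O)OCCCOC1(c2ccc(Cl)cc2)c2ccccc2C(=O)N1Cc1ccccc1`) keeps the shared core but exchanges the chain on its oxygen: 2-(((1-amino-2-methylpropyl)carbonyl)oxy)ethyl in place of 1-(acetoxymethyl)-1-methylethyl on a saturated chain carbon bound to an oxygen on a saturated carbon. Within the data shown here, the only measured step on this chain, a 1.2-fold lower number from compound 2 to compound 3 (0.07 log units; within the scatter), adds an acetyl at the far end and stays within the scatter. The closest measured relative is compound 1, also an amino-bearing ester, at 43000 nM. No step beyond the scatter is therefore expected in this assay, and the expected step is a 1.4-fold lower number from compound 3 to compound 4 (0.15 log units; within the scatter). For compound 4 the estimated value is 50000 nM, with an expected range from 22000 nM to 100000 nM.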

Compound 4, concentration for 50% growth inhibition: 65000 nM
For compound 4 the middle estimate is 1.3-fold (0.11 log units) below the measured one; the measured number falls inside the stated range.
By their numbers in this assay, from the lowest: compounds 1, 4, 3 and 2 (each within the scatter of the next).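

In this assay, exchanging the whole chain on the oxygen still leaves the number within the scatter, with a 1.1-fold lower number from compound 3 to compound 4 (0.03 log units; within the scatter) and with a 1.3-fold lower number from compound 2 to compound 4 (0.10 log units; within the scatter) as well. Changing the amino ester itself, isopropyl in place of phenyl on a saturated chain carbon bound to an amine nitrogen and a carbonyl carbon, gives a 1.5-fold higher number from compound 1 to compound 4 (0.18 log units; within the scatter) and so does not clearly move the number either. Nothing available here gives a reason for these results. Going by these compounds, whether a carboxylic acid or a much longer chain at this place would shift the number beyond the scatter remains open.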